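The source may report more compounds than this note shows. Statements on the series, on what has been measured and on what is new or still open speak of the compounds shown alone.

Compound 1 `CC(C)c1ccccc1NC(=O)N[C@H](C)c1ccccc1` gives 17% in an ADME assay on the whole organism with Oryza sativa as the target, tested at 10 uM; on this read-out lower numbers stand for a stronger effect and higher numbers for a weaker effect at the one concentration tested. Compound 2 `CC(C)c1ccccc1NC(=O)N[C@@H](C)c1ccccc1` gives 93%. Compound 3 `CC(=O)c1ccc(NC(=O)N[C@@H](C)c2ccccc2)cc1` gives 96%.

Among these three numbers compound 2 stands second highest in this assay; compound 3 is nearest, within the scatter, and compound 1 is furthest, beyond it. Among the measured compounds shown here, the only step between compounds that differ in one place is a number 76 percentage points higher from compound 1 to compound 2 (beyond the scatter), a large one that rests on the fact that compounds 1 and 2 differ only in the configuration as drawn alone, since the two compounds share every atom and bond. Compound 4 `C[C@H](NC(=O)Nc1ccccc1I)c1ccccc1` differs from compound 2 by iodo in place of isopropyl on an aromatic carbon. For the measured compounds named here, no measured step changes a substituent on that ring, so the configurational step does not bear on this change. What can be said is that compounds 2 and 3, which carry different groups on the ring and the same configuration as drawn, both give numbers in the same region. On that basis the step is expected to be a number 5 percentage points lower from compound 2 to compound 4 (within the scatter), not beyond the scatter. Compound 4 is therefore estimated at 88%, with a range from 55% to 100%.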

Compound 4, a percentage reported as activity, at one concentration (the size of the read-out at that concentration, not a potency): 98%
For compound 4 the middle estimate is 10 percentage points below the measured one; low and high end bracket the measured number.
By their numbers in this assay, from the lowest: compound 1; then compounds 2, 3 and 4 (each within the scatter of the next).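

Among the compounds shown here, this is the first step that changes a substituent on the ring rather than the configuration as drawn: iodo in place of isopropyl on an aromatic carbon, ortho to a large group, gives a number 5 percentage points higher from compound 2 to compound 4 (within the scatter) in this assay. In this configuration, the position therefore holds either group, three carbons or a single iodine, without a change beyond the scatter. Nothing on record about these compounds bears on why this is so.

From the compounds shown here alone, whether the same swap would leave the number unchanged in the configuration of compound 1, which gives 17%, remains open. So does the effect of an amine, a carboxylic acid or a longer chain at this position.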